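A methyl added to compound 3

A few compounds are considered here, and "the series" means these few. Any claim that something is new, unique, unknown or untested is made for them only; others in the source may bear on it.

Values in a functional assay on the whole organism (stomach) for inhibition, with Rattus norvegicus as the target; a higher number here means that more compound is needed for the effect, a lower number that less compound is needed:
Compound 1 `O=C(O)CCC/C=C1\CC2C[C@@H](O)[C@H](/C=C/[C@@H](O)c3ccc4c(c3)OCCO4)C2C1`: > 0.3 mg/kg, a limit
Compound 2 `O=C(O)CCC/C=C1\CC2C[C@@H](O)[C@H](/C=C/[C@@H](O)C3COc4ccccc4O3)C2C1`: 0.0045 mg/kg
Compound 3 `O=C(O)CCC/C=C1\CC2C[C@@H](O)[C@H](/C=C/[C@@H](O)C3Cc4ccccc4C3)C2C1`: 0.0562 mg/kg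

Of the two exact numbers, the higher belongs to compound 3, and the gap is large: a 12-fold higher number from compound 2 to compound 3 (1.10 log units; beyond the scatter). Compound 4 `CC1([C@H](O)/C=C/[C@@H]2C3C/C(=C/CCCC(=O)O)CC3C[C@H]2O)Cc2ccccc2C1` differs from compound 3 by methyl in place of hydrogen on a saturated ring carbon, with methyl in place of hydrogen on a saturated ring carbon. For the measured compounds named here, no measured step makes this change. The nearest steps exchange the whole ring group, namely a 12-fold higher number from compound 2 to compound 3 (1.10 log units; beyond the scatter) and an at least 5.3-fold lower number from compound 1 to compound 3 (0.72 log units; beyond the scatter). For this smaller change, no step beyond the scatter is expected, though those steps argue for a wide range. The expected step is a 1.1-fold lower number from compound 3 to compound 4 (0.05 log units; within the scatter). For compound 4 the estimate is 0.05 mg/kg, with an expected range of 0.012 mg/kg to 0.25 mg/kg.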

Compound 4, dose for half-maximal effect: 0.0452 mg/kg
Estimate against measurement, compound 4: 1.1-fold (0.04 log units) above, within the range that was stated.
By their numbers in this assay, from the lowest: compound 2; then compounds 4 and 3 (each within the scatter of the next). At a limit, above all of these: compound 1.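

In this assay, methyl in place of hydrogen on this saturated ring carbon gives a 1.2-fold lower number from compound 3 to compound 4 (0.09 log units; within the scatter), so compound 4 stands level with compound 3. The exchange of the whole ring group still separates the compounds, with a 10-fold higher number from compound 2 to compound 4 (1.00 log units; beyond the scatter). Compound 1 stands at a limit, and an at least 6.6-fold lower number from compound 1 to compound 4 (0.82 log units; beyond the scatter) is only a bound: the limit of > 0.3 mg/kg in this assay, at which 1 of the 4 values shown sits.

From the compounds shown here alone, whether an ethyl, a hydroxyl or an amine on this same ring carbon would also leave the number in place remains open. So does whether a methyl would do the same on the 2,3-dihydro-1,4-benzodioxin-2-yl group of compound 2.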